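Demethylation at the aryl oxygen in the diaryl urea series

The source may report more compounds than this note shows. Statements on the series, on what has been measured and on what is new or still open speak of the compounds shown alone.

Compound 1 `O=C(Nc1cccc(-n2cc(-c3ccncc3)c(-c3ccc(Cl)c(O)c3)n2)c1)Nc1cccc(C(F)(F)F)c1` and compound 2 `COc1cc(-c2nn(-c3cccc(NC(=O)Nc4ccc(Cl)c(C(F)(F)F)c4)c3)cc2-c2ccncc2)ccc1Cl` share the same core and differ in the urea aryl ring and in the oxygen substituent on the chlorophenyl ring. In a functional assay on TK-10 cells (Homo sapiens) for inhibition, read by sulforhodamine B assay, with a stated time of 48 h (on this read-out lower numbers stand for higher toxicity in this test and higher numbers for lower toxicity in this test), compound 1 gives no number, only a limit, > 32500 nM. In this assay compound 2 likewise returns only a limit, > 32500 nM. Compound 2 thus stands at the limit, where both values shown sit (the limit of > 32500 nM in this assay, at which 2 of the 2 values shown sit), and no order between the two compounds can be read from them.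

Compound 3 `O=C(Nc1cccc(-n2cc(-c3ccncc3)c(-c3ccc(Cl)c(O)c3)n2)c1)Nc1ccc(Cl)c(C(F)(F)F)c1` continues from compound 2 with one change: hydrogen in place of methyl on an oxygen on an aromatic ring. Among the measured compounds shown here, no measured pair isolates this change. Compound 1, which already carries the 4-chloro-3-hydroxyphenyl group, also sits at the limit > 32500 nM, so the step is expected to lie within the scatter, a step that the limit leaves unreadable from compound 2 to compound 3. Compound 3 is therefore estimated at 50000 nM, with a range from 20000 nM to 150000 nM, most probably reported again as a limit.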

Compound 3, concentration lethal to 50% of the cells: > 32500 nM
Compound 3 gave a limit, no number; the forecaster's own chance of this, stated with the estimate: 85%; the middle value is on the limit's open side.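

Compound 3 gives only a limit, so no step can be read from compound 2 to compound 3 or from compound 1 to compound 3 in this assay: the limit of > 32500 nM in this assay, at which 3 of the 3 values shown sit.

Going by these compounds, whether methoxy to hydroxy, or chloro in place of hydrogen, changes the read-out in this assay at all remains open.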